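A few compounds are considered here, and "the series" means these few. Any claim that something is new, unique, unknown or untested is made for them only; others in the source may bear on it.

Series notes. Compound 1 `O=C1CCC(N2C(=O)c3cccc(Nc4ccccn4)c3C2=O)C(=O)N1` and compound 2 `Cc1ccccc1Nc1cccc2c1C(=O)N(C1CCC(=O)NC1=O)C2=O` share one core and differ only in the group carried on a nitrogen on an aromatic ring. In an assay on FRT-Jurkat cells for inhibition of nuclear factor NF-kappa-B complex (Homo sapiens), read by flow cytometry, with a stated time of 24 h, tested at 10 uM (a lower number here means less inhibition, a higher number more inhibition at the concentration tested (going by the name of the read-out)), compound 1 gives 1%. In this assay compound 2 gives 7%. Among the compounds with values here, the single measured step, a number 6 percentage points higher from compound 1 to compound 2 (within the scatter), lies within the scatter, so the two numbers are read as equal. Compound 2 holds the higher of the two numbers, but since the gap to compound 1 is within the scatter, no order between them is claimed.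

Compound 3 `CC(C)c1ccc(Nc2cccc3c2C(=O)N(C2CCC(=O)NC2=O)C3=O)cc1` is the next member. Against compound 2 it changes in one place: 4-isopropylphenyl in place of 2-methylphenyl on a nitrogen on an aromatic ring. Within the data shown here, the only step that bears on this change is a number 6 percentage points higher from compound 1 to compound 2 (within the scatter), where exchanging the group on the nitrogen left the number unchanged. No step beyond the scatter has been seen in the series, so none is expected here either. For compound 3 the expected step is no change at the digits printed from compound 2 to compound 3 (within the scatter), with no direction implied. In this assay compound 3 is expected to give 7%, with a range from 0% to 20%.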

Compound 3, a percentage reported as inhibition, at one concentration (the size of the read-out at that concentration, not a potency): 19%
For compound 3 the middle estimate is 12 percentage points below the measured one; the measured number falls inside the stated range.
By their numbers in this assay, from the lowest: compounds 1 and 2 (each within the scatter of the next); then compound 3.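

In this assay this position now shows that the group on the nitrogen can move the number: a number 12 percentage points higher from compound 2 to compound 3 (beyond the scatter) comes with 4-isopropylphenyl in place of 2-methylphenyl, whereas the earlier exchange on this nitrogen stayed within the scatter. The exchange of pyridin-2-yl for 4-isopropylphenyl points the same way, with a number 18 percentage points higher from compound 1 to compound 3 (beyond the scatter) as the second step beyond the scatter, so compound 3 stands apart from both compound 1 and compound 2, while those two remain within the scatter of each other. No measurement at hand bears on why the number differs at this position.

The compounds shown leave open whether the step belongs to the isopropyl group itself or to the loss of the 2-methyl group, as 2-methylphenyl and 4-isopropylphenyl are the only carbon-only aryl groups on this nitrogen here. Also open, from the compounds shown here alone, is how this assay would read with a phenyl ring carrying a carboxylic acid or an amine, or with a longer alkyl chain in place of the isopropyl group.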